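This account rests on a few compounds, and the source may have more. Where it says the series, first, only, none or still open, it means among the compounds named here.

Measured compounds:
- compound 1 `Cc1cc(-c2c(C)nn(-c3nc(-c4ccc(Cl)c(Cl)c4)c(SC(C)C)s3)c2C(=O)O)cc(C)n1`: 580 nM
- compound 2 `COc1cc(C#N)cc(-c2c(C)nn(-c3nc(-c4ccc(Cl)c(Cl)c4)c(SC(C)C)s3)c2C(=O)O)c1`: 5200 nM
- compound 3 `Cc1nn(-c2nc(-c3ccc(Cl)c(Cl)c3)c(SC(C)C)s2)c(C(=O)O)c1-c1cnn(C)c1`: 6800 nM

Three compounds share a core and differ only in the group attached to one aromatic carbon of it. In a functional assay on BJAB cells (Homo sapiens) for antiproliferative activity, with a stated time of 4 days (on this read-out higher numbers stand for an effect only at larger amounts of compound and lower numbers for an effect already at smaller amounts), compound 1 gives 580 nM, compound 2 gives 5200 nM and compound 3 gives 6800 nM. Compound 3 therefore stands at the highest number of the three; the gap to compound 2 is within the scatter, while a 12-fold higher number from compound 1 to compound 3 (1.07 log units; beyond the scatter) is large, as is a 9.0-fold higher number from compound 1 to compound 2 (0.95 log units; beyond the scatter).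

Compound 4 `Cc1nn(-c2nc(-c3ccc(Cl)c(Cl)c3)c(SC(C)C)s2)c(C(=O)O)c1-c1ccccc1Cl` is not yet measured. It differs from compound 3 in one place: 2-chlorophenyl in place of 1-methyl-1H-pyrazol-4-yl on an aromatic carbon. For the measured compounds named here, no measured step introduces 2-chlorophenyl, so the only guidance is indirect. The two steps that change this same group, a 12-fold higher number from compound 1 to compound 3 (1.07 log units; beyond the scatter) and a 1.3-fold higher number from compound 2 to compound 3 (0.12 log units; within the scatter), show that a six-membered carbon ring bearing substituents, as in compound 2, sits close to compound 3, whereas 2,6-dimethylpyridin-4-yl in compound 1 sits far lower. For compound 4 a step toward a lower number than compound 3 is expected, estimated at a 2.7-fold lower number from compound 3 to compound 4 (0.43 log units; beyond the scatter), with wide uncertainty. The expected value for compound 4 is 2500 nM, within a range from 600 nM to 10000 nM.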

Compound 4, half-maximal effective concentration: 13100 nM
Beside the measured number, compound 4's estimate is 5.2-fold (0.72 log units) below it; measured number above the stated range.
By their numbers in this assay, from the lowest: compound 1; then compounds 2, 3 and 4 (each within the scatter of the next, the first and the last beyond it).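

In this assay the swap to 2-chlorophenyl gives a 1.9-fold higher number from compound 3 to compound 4 (0.28 log units; within the scatter) and so does not separate compound 4 from compound 3, even though the entering ring is a six-membered carbon ring with no hydrogen-bond acceptors and the leaving ring is a five-membered ring with two nitrogens. Measured against the other two groups, this position shows a 2.5-fold higher number from compound 2 to compound 4 (0.40 log units; beyond the scatter) and a 23-fold higher number from compound 1 to compound 4 (1.35 log units; beyond the scatter) and so leaves 2,6-dimethylpyridin-4-yl in compound 1 clearly apart from all three other groups shown. Nothing available here explains why this group stands apart.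

Going by these compounds, it remains open whether the ring nitrogen or the two methyl groups of compound 1 matter more, which a pyridine ring without methyl groups or a dimethylphenyl ring could help to separate. On these data alone, it is also open how an amine on the ring at this position would behave.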